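The source may report more compounds than this note shows. Statements on the series, on what has been measured and on what is new or still open speak of the compounds shown alone.

Measured compounds:
Compound 1, `CNC(=O)c1cc(-c2ccc(F)cc2F)ccc1OC(C)=O`: in a functional assay on the whole organism (strain Kunming) for inhibition, with Mus musculus as the target, in the writhing test, at a dose of 40 mg/kg by the oral route (a higher number here means more inhibition at the dose given (going by the name of the read-out), a lower number less inhibition), compound 1 gives 29.9%.
Compound 2, `CCNC(=O)c1cc(-c2ccc(F)cc2F)ccc1OC(C)=O`: in this assay compound 2 gives 23.9%.
Compound 3, `CC(=O)Oc1ccc(-c2ccc(F)cc2F)cc1C(=O)Nc1ccccc1C`: in this assay compound 3 gives 12.3%.

Compound 3 stands lowest of the three numbers, below compound 2 and further still below compound 1, and both of those gaps lie beyond the usual scatter. Compound 4, `CC(=O)Oc1ccc(-c2ccc(F)cc2F)cc1C(=O)Nc1cccc(C)c1`, is not yet measured. It differs from compound 3 by 3-methylphenyl in place of 2-methylphenyl on an amide-type nitrogen.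

Two measured steps reach compound 3: a number 17.6 percentage points lower from compound 1 to compound 3 (beyond the scatter) and a number 11.6 percentage points lower from compound 2 to compound 3 (beyond the scatter). Both replace a small saturated group on the amide-type nitrogen with 2-methylphenyl and both lower the number modestly. For the measured compounds named here, neither step compares two methylphenyl groups with each other, so no measured step bears directly on the change from compound 3 to compound 4. Without such a step, no change beyond the scatter is expected for compound 4. The expected step is therefore a number 1.7 percentage points higher from compound 3 to compound 4 (within the scatter). Compound 4 is estimated at 14%, in a range from 4% to 26%.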

Compound 4, a percentage reported as inhibition, in the whole organism at one dose (the size of the read-out at that dose, not a potency): 19%
For compound 4 the middle estimate is 5 percentage points below the measured one, and the stated range covers the measured number.
By their numbers in this assay, from the lowest: compounds 3, 4, 2 and 1 (each within the scatter of the next, the first and the last beyond it).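

In this assay, exchanging 2-methylphenyl for 3-methylphenyl on the amide-type nitrogen gives a number 6.7 percentage points higher from compound 3 to compound 4 (within the scatter) and so does not clearly separate the two compounds, although their atoms are joined differently. Against the smaller groups on that nitrogen, ethyl cannot be told apart from 3-methylphenyl, with a number 4.9 percentage points lower from compound 2 to compound 4 (within the scatter) as the step, whereas methyl stays clearly ahead, with a number 10.9 percentage points lower from compound 1 to compound 4 (beyond the scatter) as the step, so both methylphenyl groups lie clearly under methyl. Nothing available explains these differences.

Open, going by these compounds, is how this position would respond to a plain phenyl, a propyl chain or a group carrying an amine or a carboxylic acid. All these numbers also come from one dose, so they leave open how the compounds would compare at other doses.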